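The source may report more compounds than this note shows. Statements on the series, on what has been measured and on what is new or still open speak of the compounds shown alone.

In an assay on isolated protein for inhibition of protein kinase C theta type (Homo sapiens), read by TR-FRET, with a stated time of 2 h (on this read-out lower numbers stand for stronger inhibition and higher numbers for weaker inhibition), compound 2 `CC1(C)C[C@H](Nc2nc(NCc3cnccc3C(F)(F)F)ncc2C#N)CC[C@@H]1O` gives 6 nM, compound 3 `CC1(C)[C@H](O)C[C@H]1Nc1nc(NCc2cnccc2C(F)(F)F)ncc1C#N` gives 130 nM, and compound 1 `N#Cc1cnc(NCc2ccccc2C(F)(F)F)cc1N[C@H]1CC[C@H](O)CC1` gives 4000 nM. Compound 3 therefore stands second highest of the three numbers: the nearest is compound 2 and the furthest compound 1. For the measured compounds named here, the one change among the measured compounds that touches compound 3 is a 22-fold higher number from compound 2 to compound 3 (1.34 log units; beyond the scatter), a swap of the saturated ring that carries the hydroxyl.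

Compound 4 `CC1(C)[C@@H](Nc2nc(NCc3cnccc3C(F)(F)F)ncc2C#N)C[C@@H]1O` is a different kind of change: the two compounds have the same atoms and bonds and differ only in configuration as drawn: 2 of 2 stereo elements differ (all stereocentres are inverted: mirror images); a stereocentre at a saturated ring carbon is drawn R in compound 3 and S in compound 4; a stereocentre at a saturated ring carbon is drawn R in compound 3 and S in compound 4. It is the mirror image of compound 3. Going by the values given here, no measured pair shows what turning a stereocentre this way does to this assay, so the step from compound 2 to compound 3 gives only a feel for how much the hydroxyl-bearing ring matters, not its handedness. Mirror images often differ in this kind of assay, in either direction, so a step beyond the scatter is expected but its direction is open; the expected step is a 3.1-fold higher number from compound 3 to compound 4 (0.49 log units; beyond the scatter). Compound 4 is estimated at 400 nM, within a wide range from 50 nM to 4000 nM.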

Compound 4, half-maximal inhibitory concentration: 170 nM
For compound 4 the middle estimate is 2.4-fold (0.37 log units) above the measured one; measured number inside the range.
By their numbers in this assay, from the lowest: compound 2; then compounds 3 and 4 (each within the scatter of the next); then compound 1.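

In this assay, handedness at the 3-hydroxy-2,2-dimethylcyclobutyl group makes no difference that can be read, with a 1.3-fold higher number from compound 3 to compound 4 (0.12 log units; within the scatter). This is a clean test of handedness alone at this position: the fact that compounds 3 and 4 differ only in the configuration as drawn. Both mirror images therefore lie far from the 4-hydroxy-3,3-dimethylcyclohexyl compound, as a 28-fold higher number from compound 2 to compound 4 (1.45 log units; beyond the scatter) joins a 22-fold higher number from compound 2 to compound 3 (1.34 log units; beyond the scatter), so the large loss goes with the swap of ring and does not depend on which mirror image is drawn.

From the compounds shown here alone, it remains open whether inverting only one of the two stereocentres would leave the number just as unchanged, and whether handedness matters on the cyclohexyl ring of compound 2. Also open, going by these compounds, is what an amine in place of the hydroxyl on the cyclobutyl ring would do in this assay.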